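Ureido in place of trifluoromethyl on the sulfonamide aryl

The compounds below may be only part of what the source reports. "The series", "measured", "known", "first", "only" and "open" are said of these compounds alone.

Compound 1 `O=C(Nc1ccc(-c2noc(-c3cccc(NS(=O)(=O)c4ccc(C(F)(F)F)cc4)c3)n2)c(Cl)c1)c1cccnc1` carries a trifluoromethyl on the sulfonyl-bearing aryl ring. In a functional assay on MDA-MB-231 cells (Homo sapiens) for antiproliferative activity, read by MTT assay, with a stated time of 72 h (on this read-out lower numbers stand for stronger inhibition and higher numbers for weaker inhibition), compound 1 gives > 10000 nM, which is a limit of the assay and not a number. Two related compounds frame it. Compound 2 `CC(=O)Nc1ccc(S(=O)(=O)Nc2cccc(-c3nc(-c4ccc(NC(=O)c5cccnc5)cc4)no3)c2)cc1` gives 5200 nM in this assay. Compound 3 `CC(=O)Nc1ccc(S(=O)(=O)Nc2cccc(-c3nc(-c4ccc(NC(=O)c5cccnc5)cc4C(F)(F)F)no3)c2)cc1`, in this assay, gives > 10000 nM, again a limit. Within the data shown here, the one single-point change among them, an at least 1.9-fold higher number from compound 2 to compound 3 (0.28 log units; that floor lies within the scatter), sits against (the limit of > 10000 nM in this assay, at which 2 of the 3 values shown sit), so its true size is not known. Compound 4 `NC(=O)Nc1ccc(S(=O)(=O)Nc2cccc(-c3nc(-c4ccc(NC(=O)c5cccnc5)cc4Cl)no3)c2)cc1` differs from compound 1 by ureido in place of trifluoromethyl on an aromatic carbon. Among the measured compounds shown here, no measured step covers this exact swap, and the step from compound 2 to compound 3 concerns a different place, so it bears on the change only loosely; the pair compound 1 and compound 2 shows that a nitrogen-bearing group at this position can go with a measured number rather than a limit. Compound 4 is therefore expected near 8000 nM, within 3000 nM to 20000 nM, an estimated step of an at least 1.2-fold lower number from compound 1 to compound 4 (0.09 log units; that floor lies within the scatter) that may not exceed the scatter.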

Compound 4, half-maximal inhibitory concentration: 2800 nM
Compound 4: middle estimate off by 2.9-fold (0.46 log units), on the high side, and the stated range ends above it.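

In this assay, ureido in place of trifluoromethyl on the sulfonamide aryl ring, with the rest of the molecule unchanged, gives an at least 3.5-fold lower number from compound 1 to compound 4 (0.55 log units; beyond the scatter), so activity in these cells does respond to the group at this position. Among these compounds, until now no measured pair differed at this place alone, which makes this the first direct reading of it. The value of compound 1, > 10000 nM, is a limit of the assay and not a number, so the full size of the step stays unknown: the limit of > 10000 nM in this assay, at which 2 of the 4 values shown sit.

Ureido brings hydrogen-bond donors and an acceptor where trifluoromethyl has none, but one pair cannot tell whether these account for the step. Going by these compounds, how a simple amine, a carboxylic acid or a longer chain on the ureido would fare at this position remains open.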